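Swapping One Group on a Carbonyl Carbon

The source may hold more compounds than are shown below. What is called first, only, known or untested is meant among the compounds shown, and "the series" means these compounds.

In a functional assay on PBMC cells (Homo sapiens) for antiproliferative activity (on this read-out higher numbers stand for weaker inhibition and lower numbers for stronger inhibition), compound 1 `CN(C(=O)Nc1ccc2c(-c3ccncc3)c[nH]c2c1)c1ccccc1` gives 12000 nM. Going by the values given here, the only other measured compound, compound 2 `c1ccc(-c2ccc3c(-c4ccncc4)c[nH]c3c2)cc1`, gives 10000 nM. These two numbers lie within the usual scatter of repeated measurements, so compound 1 stands level with compound 2 and neither can be ranked. Compound 3 `O=C(NOCc1ccccc1)Nc1ccc2c(-c3ccncc3)c[nH]c2c1` keeps the core of compound 1 but carries (benzyloxy)amino in place of methyl(phenyl)amino on a carbonyl carbon. Among the compounds with values here, no measured pair yet shows what a swap of this kind does. Compound 1 at 12000 nM and compound 2 at 10000 nM differ outside the shared core yet give matching numbers, so a large shift is not expected here. The expected step is a 1.7-fold lower number from compound 1 to compound 3 (0.23 log units; within the scatter), with no change beyond the scatter in this assay. For compound 3 the estimate is 7000 nM, with an expected range from 1500 nM to 20000 nM.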

Compound 3, half-maximal inhibitory concentration in the PBMC assay: 4600 nM
Compound 3: the middle estimate sits 1.5-fold (0.18 log units) above what was measured; the measured number falls inside the stated range.
By their numbers in the PBMC assay, from the lowest: compound 3; then compounds 2 and 1 (each within the scatter of the next).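

Going by these compounds alone, this is the first measured swap on this carbonyl carbon: in the PBMC assay compound 1 gives 12000 nM and compound 3 gives 4600 nM, so the change gives a 2.6-fold lower number from compound 1 to compound 3 (0.42 log units; beyond the scatter) and moves the number beyond the scatter. The group held here can therefore alter the read-out: (benzyloxy)amino, with one hydrogen-bond donor and one acceptor where methyl(phenyl)amino has neither, goes with modestly stronger inhibition in this single pair. Nothing measured here explains the shift.

In a physicochemical assay for solubility, at pH 7.4 (on this read-out higher numbers stand for higher solubility and lower numbers for lower solubility), compound 3 gives 3.2 ug/mL and compound 1 is recorded as "not determined" (no result reported), so what the swap does to solubility cannot be read. As far as these compounds go, it also remains open how the number would move with a plain amine on the carbonyl carbon, or with a longer chain in place of the benzyl part of (benzyloxy)amino.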